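A few compounds are considered here, and "the series" means these few. Any claim that something is new, unique, unknown or untested is made for them only; others in the source may bear on it.

Measured compounds and their results:
compound 1, `COc1ccc(Cn2cc(/C=N\NC(=O)c3c[nH]c4ccccc34)c3cc(OC)ccc32)cc1`, gives 15000 nM in a functional assay on MCF7 cells (Homo sapiens) for cytotoxicity; on this read-out lower numbers stand for stronger inhibition and higher numbers for weaker inhibition;
compound 2, `COc1ccc2c(c1)c(/C=N\NC(=O)c1c[nH]c3ccc(Br)cc13)cn2Cc1ccc(Cl)cc1`, gives 29100 nM in this assay;
compound 3, `COc1ccc2c(c1)c(/C=N\NC(=O)c1cn(C)c3ccccc13)cn2Cc1ccc(Cl)cc1`, gives 99100 nM in this assay.

Compound 3 stands at the highest number of the three; compound 2 is nearest and compound 1 furthest, both beyond the scatter. Compound 4, `COc1ccc2c(c1)c(/C=N\NC(=O)c1c[nH]c3ccccc13)cn2Cc1ccc(Cl)cc1`, differs from compound 3 by hydrogen in place of methyl on an aromatic nitrogen. Among the compounds with values here, only one measured step touches this change: a 3.4-fold higher number from compound 2 to compound 3 (0.53 log units; beyond the scatter), a modest rise that came with the methyl entering the indole nitrogen together with loss of the bromine, so it carries only part of the picture. Compound 1, which also bears the unmethylated indole, and compound 3 show numbers that differ in the same direction. On that basis a drop back toward the numbers of compound 2 and compound 1 is expected in this assay, of about a 4.0-fold lower number from compound 3 to compound 4 (0.60 log units; beyond the scatter). Compound 4 is therefore estimated at 25000 nM, within a range from 8000 nM to 80000 nM.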

Compound 4, half-maximal inhibitory concentration: 8700 nM
Estimate against measurement, compound 4: 2.9-fold (0.46 log units) above; the range from low to high includes it.
By their numbers in this assay, from the lowest: compounds 4, 1 and 2 (each within the scatter of the next, the first and the last beyond it); then compound 3.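

In this assay the methyl on the aromatic nitrogen can now be read alone, and hydrogen in its place gives an 11-fold lower number from compound 3 to compound 4 (1.06 log units; beyond the scatter) as a large step, whereas the earlier step to compound 3 carried the loss of the bromine with it. The position bearing the bromine matters too, since hydrogen in place of bromo on an aromatic carbon gives a 3.3-fold lower number from compound 2 to compound 4 (0.52 log units; beyond the scatter) as a modest step, while chloro in place of methoxy on an aromatic carbon gives a 1.7-fold lower number from compound 1 to compound 4 (0.24 log units; within the scatter) and so shows no change that can be told from scatter. From the compounds shown here alone, whether an ethyl group, a longer chain or a chain ending in an amine on that nitrogen would follow the methyl remains open. So does whether the methyl would weigh the same in a compound that keeps the bromine. The compounds come with no measurement that speaks to the cause of these steps.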